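Trading a Sulfanyl Group for a Sulfonyl Group

The compounds below may be only part of what the source reports. "The series", "measured", "known", "first", "only" and "open" are said of these compounds alone.

For the measured compounds named here, in a functional assay on DU-145 cells (Homo sapiens) for inhibition, read by trypan blue exclusion, with a stated time of 96 h (on this read-out higher numbers stand for weaker inhibition of growth and lower numbers for stronger inhibition of growth), compound 2 `COc1cc(OC)c(/C=C(/SCc2ccc(Cl)c(Cl)c2)C(=O)c2ccc(Cl)cc2)c(OC)c1` gives 10000 nM and this is the only true number available so far. Compound 1 `COc1cc(OC)c(/C=C(\C(=O)c2ccc(Br)cc2)S(=O)(=O)c2ccc(Br)cc2)c(OC)c1` reads > 100000 nM and that entry is a limit of the assay, not a number.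

Compound 3 `COc1cc(OC)c(/C=C(\C(=O)c2ccc(Cl)cc2)S(=O)(=O)c2ccc(Br)cc2)c(OC)c1` has yet to be measured. Compared with compound 2, it has (4-bromophenyl)sulfonyl in place of (3,4-dichlorobenzyl)sulfanyl on a double-bonded chain carbon bound to a carbonyl carbon and a double-bonded chain carbon.

Going by the values given here, no two measured compounds differ in just one place, so no measured step shows what this swap does on its own. The best clue is compound 1, which also carries (4-bromophenyl)sulfonyl and whose limit of > 100000 nM in this assay points toward weak growth inhibition for compound 3. The estimated step of a 6.0-fold higher number from compound 2 to compound 3 (0.78 log units; beyond the scatter) is therefore expected to run toward weaker inhibition, beyond the usual scatter. For compound 3 the expected value is 60000 nM with an estimated range from 20000 nM to 150000 nM and the assay may well report only a limit.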

Compound 3, concentration for 50% growth inhibition: > 100000 nM
Compound 3: no number, only a limit; the forecaster's own chance of this, stated with the estimate: 50%; at least 1.6-fold (0.22 log units) between middle value and limit.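

In this assay, putting (4-bromophenyl)sulfonyl in place of (3,4-dichlorobenzyl)sulfanyl on a double-bonded chain carbon bound to a carbonyl carbon and a double-bonded chain carbon gives an at least 10-fold higher number from compound 2 to compound 3 (1.00 log units; beyond the scatter), so this single change is now seen to go with clearly weaker inhibition of growth. Compound 3 reads > 100000 nM, which is a limit of the assay and not a number, so the step gives only the smallest size the change can have. The step with chloro in place of bromo on an aromatic carbon cannot be read, because both entries are limits: the limit of > 100000 nM in this assay, at which 2 of the 3 values shown sit.

The swap changes several things at once: the sulfanyl becomes a sulfonyl, the benzyl becomes a phenyl, and the two chlorines give way to one bromine, so the compounds shown cannot say which of these matters. As far as these compounds go, a (3,4-dichlorobenzyl)sulfonyl group at the same place would separate the sulfur change from the ring change, and whether it would stay near compound 2 or drop to the limit remains open.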